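A few compounds are considered here, and "the series" means these few. Any claim that something is new, unique, unknown or untested is made for them only; others in the source may bear on it.

Compound 1 `CC1(C)[C@H]2CC[C@]1(C)N(Cc1cn(-c3cccc(Cl)c3)nn1)C(=O)C2`: 510 nM
Compound 2 `CC1(C)[C@H]2CC[C@]1(C)N(Cc1cn(-c3ccccc3O)nn1)C(=O)C2`: 410 nM
Compound 3 `Cc1ccc(-n2cc(CN3C(=O)C[C@@H]4CC[C@@]3(C)C4(C)C)nn2)cc1`: 390 nM

In a functional assay on SGC-7901 cells (Homo sapiens) for inhibition, read by MTT assay, with a stated time of 24 h (a higher number here means a weaker inhibitor, a lower number a stronger inhibitor), compound 3 gives 390 nM. That is the lowest of the three numbers, but its gaps to the other two are within the scatter, a 1.1-fold lower number from compound 2 to compound 3 (0.02 log units; within the scatter) and a 1.3-fold lower number from compound 1 to compound 3 (0.12 log units; within the scatter), so compound 3 cannot be called the most potent of the set; the three compounds are indistinguishable by this measure.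

Compound 4 `CC1(C)[C@H]2CC[C@]1(C)N(Cc1cn(-c3ccccc3C#N)nn1)C(=O)C2` has not been measured. It differs from compound 3 in one place: 2-cyanophenyl in place of 4-methylphenyl on an aromatic nitrogen

Every measured step bears on this change, since each one also swaps the aryl group on the aromatic nitrogen: a 1.2-fold lower number from compound 1 to compound 2 (0.09 log units; within the scatter), a 1.3-fold lower number from compound 1 to compound 3 (0.12 log units; within the scatter) and a 1.1-fold lower number from compound 2 to compound 3 (0.02 log units; within the scatter). All three were within the scatter. A 2-cyanophenyl has not been tested here, and the shared core was held fixed throughout, so there is nothing in the numbers that points to a shift in either direction beyond the scatter.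

Compound 4 is therefore expected to land close to compound 3, with a 1.1-fold higher number from compound 3 to compound 4 (0.04 log units; within the scatter) as the estimated step. The estimate for compound 4 is 430 nM, with a range from 200 nM to 950 nM.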

Compound 4, half-maximal inhibitory concentration: 260 nM
The estimate for compound 4 lay 1.7-fold (0.22 log units) above the measured number; the measured number falls inside the stated range.
By their numbers in this assay, from the lowest: compounds 4, 3, 2 and 1 (each within the scatter of the next).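

In this assay, a nitrile on the aryl group attached to the aromatic nitrogen leaves the picture as flat as the earlier swaps did: there is a 1.5-fold lower number from compound 3 to compound 4 (0.18 log units; within the scatter), a 1.6-fold lower number from compound 2 to compound 4 (0.20 log units; within the scatter) and a 2.0-fold lower number from compound 1 to compound 4 (0.29 log units; within the scatter), so the 2-cyanophenyl cannot be separated from the 4-methylphenyl, the 2-hydroxyphenyl or the 3-chlorophenyl. The step from compound 2 adds the one comparison in which two groups occupy the same aromatic carbon, and exchanging hydroxy for cyano there does not separate the two compounds, so the four aryl groups now shown all fall within the scatter of one another. Nothing measured here offers an explanation for the small differences among these numbers.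

The compounds shown leave open whether an amine, a carboxylic acid or a longer chain on the phenyl ring would produce a step beyond the scatter, since the groups seen so far are a chlorine, a hydroxy, a methyl and a nitrile. They also leave open how much the shared core and the methylene link to the five-membered ring contribute, as both are identical in all four compounds.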